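Heteroaryl Variation on a Shared Core Against Paw Edema

This account rests on a few compounds, and the source may have more. Where it says the series, first, only, none or still open, it means among the compounds named here.

Compound 1 `O=C(O)c1cc(-c2ccns2)ccc1O` is tested in a functional assay on the whole organism for inhibition, with Rattus norvegicus as the target, read by paw edema (on this read-out lower numbers stand for an effect already at smaller amounts and higher numbers for an effect only at larger amounts of compound), where compound 1 gives 80 mg/kg. Among the numbers shown this is the higher of two, with compound 2 `O=C(O)c1ccc(-c2cscn2)cc1O` giving 70 mg/kg in this assay, a gap within the scatter. Compound 3 `O=C(O)c1cc(-c2ccncn2)ccc1O` reaches only a limit of > 200 mg/kg in this assay. The step to compound 4 `O=C(O)c1cc(-c2csnn2)ccc1O` is 1,2,3-thiadiazol-4-yl in place of 1,2-thiazol-5-yl on an aromatic carbon. Within the data shown here, no step between measured compounds is available to gauge this change; the only hint is that compound 3 sits at the limit (the limit of > 200 mg/kg in this assay, at which 1 of the 3 values shown sits). The expected step of a 1.4-fold higher number from compound 1 to compound 4 (0.14 log units; within the scatter) is modest, toward a higher number, close to the scatter. Compound 4 is therefore estimated at 110 mg/kg, in a range from 50 mg/kg to 250 mg/kg.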

Compound 4, dose for half-maximal effect: > 200 mg/kg
Compound 4: a limit, no number; the forecaster's own chance of this, stated with the estimate: 30%; at least 1.8-fold (0.25 log units) between middle value and limit.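

In this assay compound 4 gives > 200 mg/kg, which is a limit and not a number. On this aromatic carbon, para to a hydroxy group, 1,2,3-thiadiazol-4-yl in place of 1,2-thiazol-5-yl gives an at least 2.5-fold higher number from compound 1 to compound 4 (0.39 log units; beyond the scatter), so a change inside the five-membered aromatic ring alone moves the read-out beyond the scatter. A five-membered aromatic ring at this place therefore does not by itself preserve the number of compound 1: the limit of > 200 mg/kg in this assay, at which 2 of the 4 values shown sit.

On these data alone, how far compound 4 lies past its limit stays open. Also open, as far as these compounds go, is what an amine or a methyl group on the 1,2-thiazol-5-yl ring would do here.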